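The source may hold more compounds than are shown below. What is called first, only, known or untested is meant among the compounds shown, and "the series" means these compounds.

Compound 1 `COc1cc(OC)c(C(=O)/C=C/c2ccc(Cl)cc2)c(O)c1CC=C(C)C` gives 43400 nM in an ADME assay on MCF7-DOX cells (Homo sapiens) for cytotoxicity, read by MTT assay, with a stated time of 48 h; on this read-out higher numbers stand for weaker inhibition and lower numbers for stronger inhibition. Compound 2 `COc1c(C)c(O)c(C)c(O)c1C(=O)/C=C/c1ccccc1` gives 46800 nM in this assay. Compound 3 `CCCc1c(OC)cc(OC)c(C(=O)/C=C/c2cccc(N3CCNCC3)c2)c1O` returns only a limit of the assay, > 100000 nM, in this assay.

Among the values shown, compound 1 holds the lowest of the two actual numbers, but the nearest value, that of compound 2, lies within the scatter of repeated measurements, so neither compound can be placed ahead of the other. Compound 3 stands at the limit of > 100000 nM in this assay, at which 1 of the 3 values shown sits. No step between measured compounds that differ in a single place is shown, so nothing here measures what a change of the aryl group does in this assay.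

Compound 4 `COc1cccc(/C=C/C(=O)c2c(OC)cc(OC)c(CC=C(C)C)c2O)c1` has not yet been measured in this assay. It differs from compound 1 in one place: 3-methoxyphenyl in place of 4-chlorophenyl on a double-bonded chain carbon bound to a double-bonded chain carbon. Going by the values given here, with no measured step of this kind to lean on, and with both numeric values already close together, the account expects the step from compound 1 to compound 4 to be a 1.4-fold higher number from compound 1 to compound 4 (0.14 log units; within the scatter), a small shift towards a higher number, though a result within the scatter is just as plausible. Compound 4 is therefore estimated at 60000 nM in this assay, with an expected range from 25000 nM to 150000 nM, and with a real chance that only a limit is reported.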

Compound 4, half-maximal inhibitory concentration: 49200 nM
Beside the measured number, compound 4's estimate is 1.2-fold (0.09 log units) above it; low and high end bracket the measured number.
By their numbers in this assay, from the lowest: compounds 1, 2 and 4 (each within the scatter of the next). At a limit, above all of these: compound 3.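

Going by these compounds alone, at this place, on a double-bonded chain carbon bound to a double-bonded chain carbon, the earlier compounds offered no step to read, and in this assay the exchange of 4-chlorophenyl for 3-methoxyphenyl now gives a 1.1-fold higher number from compound 1 to compound 4 (0.05 log units; within the scatter), so the two groups cannot be told apart on this read-out. The entering group carries a hydrogen-bond acceptor that the leaving group lacks and has a further heavy atom, yet on this single pair neither difference goes with a step beyond the scatter. Nothing measured among the compounds shown gives a reason for this outcome.

Still open, from the compounds shown here alone, is whether a group of another kind at this place, such as an amine or a carboxylic acid on the phenyl ring, would stay within the scatter as well, and whether 4-methoxyphenyl or 3-chlorophenyl would separate the effect of the group from that of where it sits. Within the data shown here, also open is whether the step would stay this small if a longer chain stood in place of the one that compound 1 and compound 4 share.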